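The compounds below may be only part of what the source reports. "The series", "measured", "known", "first", "only" and "open" are said of these compounds alone.

The measured compounds in a functional assay on MCF7 cells (Homo sapiens) for inhibition, read by MTT assay, with a stated time of 72 h; on this read-out lower numbers stand for stronger inhibition and higher numbers for weaker inhibition:
compound 1 `Cc1cc(Nc2cc(-c3ccccc3)[nH]n2)n2nc(SCc3ccc(F)cc3)nc2n1`, 4020 nM;
compound 2 `Cc1cc(Nc2cc(-c3ccccc3)[nH]n2)n2nc(SCc3ccc(Br)cc3)nc2n1`, 2720 nM;
compound 3 `Cc1cc(Nc2cc(-c3ccccc3)[nH]n2)n2nc(SCC(=O)c3ccccc3)nc2n1`, 5240 nM.

Compound 3 holds the highest of the three numbers, yet both steps leading to it, a 1.3-fold higher number from compound 1 to compound 3 (0.12 log units; within the scatter) and a 1.9-fold higher number from compound 2 to compound 3 (0.28 log units; within the scatter), stay within the scatter, so no order among the three can be claimed.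

Compound 4 `Cc1cc(Nc2cc(-c3ccccc3)[nH]n2)n2nc(SCc3ccccc3Br)nc2n1` differs from compound 3 by 2-bromophenyl in place of benzoyl on a saturated chain carbon bound to a sulfur. The step bearing most directly on this change is a 1.9-fold higher number from compound 2 to compound 3 (0.28 log units; within the scatter), whose reverse resembles the change at hand, though compound 2 carries 4-bromophenyl and compound 4 carries 2-bromophenyl. a 1.5-fold lower number from compound 1 to compound 2 (0.17 log units; within the scatter) adds that the two halogenated analogues sit within the scatter of each other. Compound 4 is therefore expected to show a step of a 1.6-fold lower number from compound 3 to compound 4 (0.21 log units; within the scatter), probably within the scatter. The estimate for compound 4 in this assay is 3200 nM, with a range from 1500 nM to 7000 nM.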

Compound 4, half-maximal inhibitory concentration: 3020 nM
For compound 4 the middle estimate is 1.1-fold (0.03 log units) above the measured one; the range from low to high includes it.
By their numbers in this assay, from the lowest: compounds 2, 4, 1 and 3 (each within the scatter of the next).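

In this assay, 2-bromophenyl in place of 4-bromophenyl gives a 1.1-fold higher number from compound 2 to compound 4 (0.05 log units; within the scatter), so this first change in where the bromine sits on the ring shows no readable effect at this place on the saturated chain carbon bound to a sulfur. The steps of a 1.7-fold lower number from compound 3 to compound 4 (0.24 log units; within the scatter) and a 1.3-fold lower number from compound 1 to compound 4 (0.12 log units; within the scatter) also stay within the scatter, so the new group cannot be told apart from benzoyl or 4-fluorophenyl here. No measurement at hand accounts for these values. The compounds shown leave open whether an amine or a carboxylic acid on this ring, or a longer chain in place of the benzyl link, would give a step beyond the scatter.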